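Fluoro for methyl on the sulfonate ring: cytotoxicity notes

A few compounds are considered here, and "the series" means these few. Any claim that something is new, unique, unknown or untested is made for them only; others in the source may bear on it.

Compound 1 `Cc1ccc(S(=O)(=O)Oc2ccc3c(CSc4nc5ccccc5c(=O)[nH]4)cc(=O)oc3c2)cc1` gives 117000 nM in an ADME assay on Vero cells (Chlorocebus sabaeus) for cytotoxicity, read by polymerase chain reaction, with a stated time of 18 h; on this read-out lower numbers stand for higher toxicity in this test and higher numbers for lower toxicity in this test. Compound 2 `O=c1cc(CSc2nc3ccccc3c(=O)[nH]2)c2ccc(OS(=O)(=O)c3ccc(F)cc3)cc2o1` carries fluoro in place of methyl on an aromatic carbon and in this assay compound 2 gives 30000 nM, a step of a 3.9-fold lower number from compound 1 to compound 2 (0.59 log units; beyond the scatter). Compound 3 `Cc1ccc(S(=O)(=O)Oc2ccc3c(CSC4=NCCC(=O)N4)cc(=O)oc3c2)cc1` differs from compound 1 by a group of 7 heavy atoms (4 carbon, 2 nitrogen, 1 oxygen; one six-membered non-aromatic ring with 2 hetero atoms) in place of a group of 11 heavy atoms (8 carbon, 2 nitrogen, 1 oxygen; one six-membered aromatic ring of carbon only, one six-membered aromatic ring with 2 hetero atoms), on a sulfur and in this assay compound 3 gives 60200 nM, a step of a 1.9-fold lower number from compound 1 to compound 3 (0.29 log units; within the scatter). Compound 4 `O=C1CCN=C(SCc2cc(=O)oc3cc(OS(=O)(=O)c4ccc(F)cc4)ccc23)N1` carries the same change on the core of compound 3, (fluoro in place of methyl on an aromatic carbon); the surroundings of the exchanged atom read the same as for compound 2. The change occurs twice among these compounds and has been measured once. For compound 4 the step is expected to be a 3.3-fold lower number from compound 3 to compound 4 (0.52 log units; beyond the scatter), set beside a 3.9-fold lower number from compound 1 to compound 2 (0.59 log units; beyond the scatter), because a 3.9-fold lower number from compound 1 to compound 2 (0.59 log units; beyond the scatter) lies beyond the scatter while a 1.9-fold lower number from compound 1 to compound 3 (0.29 log units; within the scatter) lies within it. Compound 4 is estimated at 18000 nM, expected between 7000 nM and 45000 nM.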

Compound 4, half-maximal cytotoxic concentration: 111000 nM
Compound 4: the middle estimate sits 6.2-fold (0.79 log units) below what was measured, outside the stated range (above it).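

On the core of compound 3, fluoro in place of methyl gives a 1.8-fold higher number from compound 3 to compound 4 (0.27 log units; within the scatter), so the drop seen on the core of compound 1 in this assay does not carry over: the same change on two cores in this assay, a 3.9-fold lower number (0.59 log units; beyond the scatter) from compound 1 to compound 2 and a 1.8-fold higher number (0.27 log units; within the scatter) from compound 3 to compound 4, 7.2-fold (0.86 log units) apart, beyond the scatter of two such steps

Read the other way, exchanging the group on sulfur gives a 3.7-fold higher number from compound 2 to compound 4 (0.57 log units; beyond the scatter) when the sulfonate ring carries 4-fluorophenyl, so that step also depends on its surroundings: the same change on two cores in this assay, a 1.9-fold lower number (0.29 log units; within the scatter) from compound 1 to compound 3 and a 3.7-fold higher number (0.57 log units; beyond the scatter) from compound 2 to compound 4, 7.2-fold (0.86 log units) apart, beyond the scatter of two such steps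

These four compounds show that the two changes do not add up here; they do not show why, or how fluoro for methyl would behave on any further core.

Still open, as far as these compounds go, is whether a chloro or methoxy group in place of the methyl would follow compound 2 on one core and compound 4 on the other. Also open, from the compounds shown here alone, is whether other groups on the sulfur would show the same dependence.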